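Working notes: from compound 3 to compound 4

The compounds below may be only part of what the source reports. "The series", "measured", "known", "first", "only" and "open" are said of these compounds alone.

The compounds share one core and differ in a single group on an aromatic carbon. In an ADME assay (liver) for metabolic stability, with Liver microsome (Rattus norvegicus) as the target, using microsomes and NADPH, with a stated time of 30 min, tested at 1 uM (on this read-out higher numbers stand for fast clearance and lower numbers for slow clearance), compound 1 `Nc1ccc(S(=O)(=O)N2CCN(c3ncc(C(O)(C(F)(F)F)C(F)(F)F)cc3Br)CC2)cn1` gives 32 mL.min-1.g-1 and compound 2 `Nc1ccc(S(=O)(=O)N2CCN(c3ncc(C(O)(C(F)(F)F)C(F)(F)F)cc3C3CC3)CC2)cn1` gives 27 mL.min-1.g-1, a pair separated by a 1.2-fold lower number from compound 1 to compound 2 (0.07 log units; within the scatter). Compound 3 `Cc1ccc(-c2cc(C(O)(C(F)(F)F)C(F)(F)F)cnc2N2CCN(S(=O)(=O)c3ccc(N)nc3)CC2)cn1` gives 182 mL.min-1.g-1, the highest of the three numbers. Replacing bromo with 6-methylpyridin-3-yl gives a 5.7-fold higher number from compound 1 to compound 3 (0.75 log units; beyond the scatter), and replacing cyclopropyl with the same group gives a 6.7-fold higher number from compound 2 to compound 3 (0.83 log units; beyond the scatter).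

Compound 4 `Cc1nc2cc(-c3cc(C(O)(C(F)(F)F)C(F)(F)F)cnc3N3CCN(S(=O)(=O)c4ccc(N)nc4)CC3)ccc2o1` carries 2-methyl-1,3-benzoxazol-5-yl in place of 6-methylpyridin-3-yl on an aromatic carbon. The two steps into compound 3 bear on this change only indirectly, since each brings an aromatic ring to a place that held none. Here one aromatic group replaces another, and no measured step of that kind exists, so the data give no direction. Compound 4 keeps an aromatic group at the place where compound 3 reaches 182 mL.min-1.g-1, so its number is expected to stay in the same high region. No change beyond the scatter is expected, and the estimated step is a 1.1-fold lower number from compound 3 to compound 4 (0.06 log units; within the scatter). Compound 4 is estimated at 160 mL.min-1.g-1, with an expected range from 70 mL.min-1.g-1 to 350 mL.min-1.g-1.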

Compound 4, intrinsic clearance in microsomes: 99 mL.min-1.g-1
Estimate against measurement, compound 4: 1.6-fold (0.21 log units) above; the range from low to high includes it.
By their numbers in this assay, from the lowest: compounds 2 and 1 (each within the scatter of the next); then compounds 4 and 3 (each within the scatter of the next).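

In this assay the exchange of one aromatic group for another at this position, a single six-membered ring giving way to a five-membered and a six-membered aromatic ring, gives a 1.8-fold lower number from compound 3 to compound 4 (0.26 log units; within the scatter) and stays within the scatter, so this read-out does not separate the two aromatic groups. The high clearance is also not confined to 6-methylpyridin-3-yl: with a 3.7-fold higher number from compound 2 to compound 4 (0.56 log units; beyond the scatter) and a 3.1-fold higher number from compound 1 to compound 4 (0.49 log units; beyond the scatter), both steps beyond the scatter, 2-methyl-1,3-benzoxazol-5-yl stands apart from cyclopropyl and bromo in the same direction, and no compound shown goes against this. Nothing available here accounts for this difference between the aromatic groups and the two smaller groups.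

Both aromatic groups carry a methyl, so the compounds shown cannot say whether the higher clearance goes with the aromatic rings themselves or with that methyl, and a plain phenyl would bear on this. On these data alone, how an amine such as morpholine, or a carboxylic acid, at this place would stand against bromo, cyclopropyl and the two aromatic groups also remains open.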